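From 2-carboxyphenyl to 4-methoxyphenyl on an amine nitrogen

This account rests on a few compounds, and the source may have more. Where it says the series, first, only, none or still open, it means among the compounds named here.

In a functional assay on KB cells (Homo sapiens) for cytotoxicity, read by sulforhodamine B assay (a higher number here means a weaker inhibitor, a lower number a stronger inhibitor), compound 1 (`C=C1[C@@H](OC(C)=O)C[C@@H]2[C@](C)(COC=O)[C@H](OC(C)=O)CC[C@@]2(C)[C@@H]1C[C@@H](Nc1ccccc1C(=O)O)C1=CCOC1=O`) gives 42500 nM as one of three measured compounds. Compound 2 (`C=C1[C@@H](OC(C)=O)C[C@@H]2[C@](C)(COC=O)[C@H](OC(C)=O)CC[C@@]2(C)[C@@H]1C/C=C1/C(=O)OC[C@H]1OC(C)=O`) gives 21600 nM and stays within the scatter of compound 1, whereas compound 3 (`C=C1[C@@H](OC(C)=O)C[C@@H]2[C@](C)(CO[Si](C)(C)C(C)(C)C)[C@H](OC(C)=O)CC[C@@]2(C)[C@@H]1C[C@@H](Nc1ccccc1C(=O)O)C1=CCOC1=O`) gives 6050 nM and lies clearly lower. Compound 4 (`C=C1[C@@H](OC(C)=O)C[C@@H]2[C@](C)(COC=O)[C@H](OC(C)=O)CC[C@@]2(C)[C@@H]1C[C@@H](Nc1ccc(OC)cc1)C1=CCOC1=O`) differs from compound 1 by 4-methoxyphenyl in place of 2-carboxyphenyl on an amine nitrogen on the shared core. Within the data shown here, no measured step changes the group on that nitrogen. Among the measured compounds shown here, the only measured step is a 7.0-fold lower number from compound 1 to compound 3 (0.85 log units; beyond the scatter) and it lies on an oxygen on a saturated carbon, so it is only a loose guide. The expected size is modest, with the estimate being a 2.7-fold lower number from compound 1 to compound 4 (0.42 log units; beyond the scatter) in this assay and the scatter possibly covering it. Compound 4 is estimated at 16000 nM within an expected range from 5000 nM to 50000 nM in this assay for now.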

Compound 4, half-maximal inhibitory concentration: 32700 nM
Compound 4: middle estimate off by 2.0-fold (0.31 log units), on the low side; the measured number falls inside the stated range.
By their numbers in this assay, from the lowest: compound 3; then compounds 2, 4 and 1 (each within the scatter of the next).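

Among these compounds, the first measured change on the amine nitrogen, in this assay, is a 1.3-fold lower number from compound 1 to compound 4 (0.11 log units; within the scatter), so 4-methoxyphenyl and 2-carboxyphenyl are not separated at this position. The carboxylic acid and its hydrogen-bond donor can thus be replaced here by 4-methoxyphenyl with no change beyond the scatter. Nothing available gives a reason for this result.

The compounds shown leave open whether a plain phenyl or a longer alkyl chain on that nitrogen would separate from compound 1. They also leave open whether 4-methoxyphenyl would read the same alongside the group compound 3 carries on its oxygen.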